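The source may report more compounds than this note shows. Statements on the series, on what has been measured and on what is new or still open speak of the compounds shown alone.

Measured compounds: compound 1 `CCCCCc1cccc(NC(=O)NCCCCl)c1` gives 28000 nM in a functional assay on HT-29 cells (Homo sapiens) for antiproliferative activity, with a stated time of 48 h; a higher number here means a weaker inhibitor, a lower number a stronger inhibitor; compound 2 `O=C(CCl)Nc1ccc(I)cc1` gives 9700 nM; compound 3 `CC(C)(C)c1ccc(NC(=O)CCl)cc1` gives 15000 nM.

Compound 2 holds the lowest number of the three; compound 3 sits nearest, at a 1.5-fold higher number from compound 2 to compound 3 (0.19 log units; within the scatter), and compound 1 furthest, beyond the scatter. Compound 4 `O=C(CCCCl)Nc1ccc(I)cc1` differs from compound 2 in one place: 2-chloroethyl in place of chloro on a saturated chain carbon bound to a carbonyl carbon. For the measured compounds named here, no measured step covers a chain change of this kind; the only step in hand concerns the aromatic substituent. Compound 1 carries a longer chloroalkyl chain on a urea and gives a higher number, but it differs from compound 2 in more than one place. Compound 4 is therefore expected near compound 2, at a 2.1-fold higher number from compound 2 to compound 4 (0.31 log units; beyond the scatter), with a wide range: estimate 20000 nM (6000 nM to 60000 nM).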

Compound 4, half-maximal inhibitory concentration: > 100000 nM
Compound 4: a limit, no number (the forecaster's own chance of this, stated with the estimate: 10%); at least 5.0-fold (0.69 log units) between middle value and limit.
By their numbers in this assay, from the lowest: compounds 2, 3 and 1 (each within the scatter of the next, the first and the last beyond it). At a limit, above all of these: compound 4.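

In this assay compound 4 gives > 100000 nM as a limit of the assay and not a number. The step of an at least 10-fold higher number from compound 2 to compound 4 (1.01 log units; beyond the scatter) shows that the saturated chain carbon bound to a carbonyl carbon is sensitive to the change from chloromethyl to 3-chloropropyl. The earlier step of a 1.5-fold higher number from compound 2 to compound 3 (0.19 log units; within the scatter) concerned an aromatic carbon and gave no reading of this chain.

Going by these compounds, how a propyl chain or an aminopropyl chain in place of 3-chloropropyl would read stays open. On these data alone, whether the chain or its chlorine drives the loss also stays open.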